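Phenyl on the ring nitrogen of compound 3

The source may hold more compounds than are shown below. What is called first, only, known or untested is meant among the compounds shown, and "the series" means these compounds.

Measured so far in a functional assay on HepG2 cells (Homo sapiens) for antiproliferative activity, read by MTT assay, with a stated time of 72 h; on this read-out lower numbers stand for stronger inhibition and higher numbers for weaker inhibition:
compound 1 `COc1ncc(-c2ccc3c(c2)NC(=O)CO3)cc1NS(=O)(=O)c1ccc(F)cc1`: 6590 nM
compound 2 `COc1cccc(N2C(=O)COc3ccc(-c4cnc(OC)c(NS(=O)(=O)c5ccc(F)cc5)c4)cc32)c1`: > 40000 nM (a limit)
compound 3 `CC(C)N1C(=O)COc2ccc(-c3cccc(NS(=O)(=O)c4ccc(F)cc4)c3)cc21`: > 40000 nM (a limit)

Compound 3 gives no number to work from, only a limit. It sits with compound 2 on (the limit of > 40000 nM in this assay, at which 2 of the 3 values shown sit), so the size of any step from compound 3 can only be judged loosely.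

The next compound, compound 4 `O=C1COc2ccc(-c3cccc(NS(=O)(=O)c4ccc(F)cc4)c3)cc2N1c1ccccc1`, carries phenyl in place of isopropyl on an amide-type nitrogen in a ring.

Among the compounds with values here, one measured step bears on this change. In an at least 6.0-fold higher number from compound 1 to compound 2 (0.78 log units; beyond the scatter), 3-methoxyphenyl replaces hydrogen on an amide-type nitrogen in a ring, and the number rises. That step starts from hydrogen rather than isopropyl, and the core of compound 1 differs from that of compound 3, so it is only a partial guide. It gives no ground to expect a ring on this nitrogen to bring a lower number in this assay. No step beyond the scatter is expected, and compound 4 may well reach the limit of the assay too.

The expected step is an at least 1.1-fold lower number from compound 3 to compound 4 (0.05 log units; that floor lies within the scatter).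

For compound 4 the estimate is 35000 nM, with an expected range from 12000 nM to 60000 nM.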

Compound 4, half-maximal inhibitory concentration: 30300 nM
Compound 4: the middle estimate sits 1.2-fold (0.06 log units) above what was measured; measured number inside the range.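

In this assay, phenyl in place of isopropyl on the amide-type nitrogen gives an at least 1.3-fold lower number from compound 3 to compound 4 (0.12 log units; that floor lies within the scatter), the only step shown at this position that starts from an alkyl group rather than hydrogen. It also shows that an aromatic ring on this nitrogen need not end at the limit of the assay. Compound 4 gives a real number, 30300 nM, on the core of compound 3; the only earlier ring at this position, the 3-methoxyphenyl of compound 2, sits on the core of compound 1. The step is only a floor, and its true size stays unknown, because the isopropyl compound 3 gives a limit and not a number: the limit of > 40000 nM in this assay, at which 2 of the 4 values shown sit.

No pair shown links the core of compound 1 to the core of compound 3 through a change in one place, so the part played by the core in these values remains unresolved. Also open, as far as these compounds go, is how this assay would read with hydrogen on this nitrogen of the core of compound 3, or with a longer chain ending in an amine or a carboxylic acid.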